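This account rests on a few compounds, and the source may have more. Where it says the series, first, only, none or still open, it means among the compounds named here.

Measured compounds:
compound 1, `O=C(N/N=C/c1ccc(F)cc1)c1cnccn1`, gives 71%
compound 2, `O=C(N/N=C/c1cccc(Br)c1)c1cnccn1`, gives 93%

Both compounds were tested in an ADME assay on J774 cells (Mus musculus) for cytotoxicity, read by MTT assay, with a stated time of 48 h, tested at 150 ug/mL; a lower number here means a stronger effect, a higher number a weaker effect of the compound at the concentration tested. Of the two numbers, compound 1 stands lowest: in this assay compound 1 gives 71%, while compound 2 gives 93%, a value higher by a margin that lies beyond the usual scatter. Going by the values given here, no step between these two is counted, as they differ in more than one place, so only their two values can be compared.

The account now follows compound 1 to compound 3, `N#Cc1ccc(/C=N/NC(=O)c2cnccn2)cc1`, which has not yet been measured in this assay. The change is cyano in place of fluoro on an aromatic carbon. The shared core is untouched.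

Among the compounds with values here, with only two measured compounds and no counted step, the expected size of a number 9 percentage points higher from compound 1 to compound 3 (within the scatter) rests on little; a small move upward is expected, and it may well stay within the scatter. Compound 3 is thus estimated at 80% in this assay, with a range from 62% to 96%.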

Compound 3, a percentage reported as activity, at one concentration (the size of the read-out at that concentration, not a potency): 100%
The estimate for compound 3 lay 20 percentage points below the measured number; measured number outside the range, above it.
By their numbers in this assay, from the lowest: compound 1; then compounds 2 and 3 (each within the scatter of the next).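

Going by these compounds alone, the swap of fluoro for cyano, on an aromatic carbon para to a large group, gives the first counted step in this assay: a number 29 percentage points higher from compound 1 to compound 3 (beyond the scatter). This shows that a single change at this position, with the shared core untouched, is enough to move the read-out by more than the usual scatter, and that the move runs toward a weaker effect at the concentration tested, with compound 3 at 100%. Nothing available bears on why cyano and fluoro differ in this way, so the step stands as an observation without an explanation.

The compounds shown leave open how an amine, a carboxylic acid or a methoxy group on this same aromatic carbon would read in this assay, and so whether other groups would stay near compound 1 or near compound 3. Within the data shown here, they also leave open whether this step would recur on a different background, since a single step at a single concentration describes only this one pair and establishes no trend.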